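Carbamoyl for Fluoro on an Aryl-Substituted Bicyclic Core

This account rests on a few compounds, and the source may have more. Where it says the series, first, only, none or still open, it means among the compounds named here.

Measured compounds:
compound 1, `COc1ccc(C2Cc3nccn3C2)cc1`, 27%
compound 2, `COc1cccc(C2Cc3nccn3C2)c1`, 56%
compound 3, `Fc1ccccc1C1Cc2nccn2C1`, 63%

Three compounds share one core and differ only in the substitution of the six-membered aromatic ring of carbon only. In a functional assay on CHO cells for agonist activity at Alpha-1A adrenergic receptor (Homo sapiens), read by FLIPR and calcium flux (a lower number here means a smaller maximal response, a higher number a larger maximal response), compound 1 gives 27%. Compound 2 gives 56% in this assay, and compound 3 gives 63%. The numbers of compound 3 and compound 2 lie within the scatter of each other, so no order between them can be claimed; compound 1, by contrast, stands beyond the scatter below compound 3.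

Compound 4 is `NC(=O)c1ccccc1C1Cc2nccn2C1`. It differs from compound 3 in one place: carbamoyl in place of fluoro on an aromatic carbon. Going by the values given here, no measured pair shows a change of this kind, so the data give no direct guide to its direction or size. The step in this assay from compound 3 to compound 4 is therefore expected to be uncertain, possibly downward and possibly beyond the scatter, and a step of a number 18 percentage points lower from compound 3 to compound 4 (beyond the scatter) is estimated. For compound 4 the estimate in this assay is 45%, with a range from 15% to 80%.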

Compound 4, largest response reached (Emax), in percent of the reference or control that the assay uses: 87%
Compound 4: the middle estimate sits 42 percentage points below what was measured; the measured number lies above the stated range.
By their numbers in this assay, from the lowest: compound 1; then compounds 2 and 3 (each within the scatter of the next); then compound 4.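

In this assay, carbamoyl in place of fluoro on an aromatic carbon gives a number 24 percentage points higher from compound 3 to compound 4 (beyond the scatter), so this place on the six-membered aromatic ring of carbon only, ortho to a group of 8 heavy atoms, accepts the larger group with a gain in maximal response. This is the only single-place change among the compounds shown, and it shows that replacing one heavy atom, with no hydrogen-bond donor or acceptor, by three heavy atoms carrying one hydrogen-bond donor and one hydrogen-bond acceptor need not reduce the response at this position. The compounds and data shown offer no evidence on why the response rises with this change.

From the compounds shown here alone, it remains open whether the rise is specific to carbamoyl or would also appear with a carboxylic acid, a methyl ester, a nitrile or an aminomethyl group at the same place, and whether adding a methyl group on the amide nitrogen would preserve it. The compounds shown also leave open whether carbamoyl on another aromatic carbon of this ring would produce a similar step.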